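The compounds below may be only part of what the source reports. "The series", "measured", "known", "first", "only" and "open" are said of these compounds alone.

In an in vivo ADME assay on the whole organism (Rattus norvegicus) for pharmacokinetics (on this read-out higher numbers stand for higher oral bioavailability and lower numbers for lower oral bioavailability), compound 1 `NS(=O)(=O)c1ccccc1-c1ccc(C(=O)NC(CC(=O)Nc2ccc(Br)cn2)C(=O)O)cc1` gives 4% and compound 2 `CN(C)Cc1ccccc1-c1ccc(C(=O)N[C@@H](CC(=O)Nc2ccc(Cl)cn2)C(=O)N2CCCCC2)cc1` gives 7.9% and the two values lie within the scatter of each other. Against compound 2, compound 3 `CN(C)Cc1ccccc1-c1ccc(C(=O)N[C@H](CC(=O)Nc2ccc(Cl)cn2)C(=O)N2CCCCC2)cc1` shows this difference: the two compounds have the same atoms and bonds and differ only in configuration as drawn: 1 of 1 stereo elements differ; a stereocentre at a saturated chain carbon is drawn S in compound 2 and R in compound 3 with a stereocentre at a saturated chain carbon drawn S in compound 2 and R in compound 3. Among the measured compounds shown here, no measured pair shows such a change, so the expected shift in this assay is none beyond the scatter, in neither direction. The estimated step of a number 0.1 percentage points higher from compound 2 to compound 3 (within the scatter) stays within that scatter. For compound 3 the estimated value is 8% with an expected range of 2% to 18% in this read-out.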

Compound 3, oral bioavailability: 25.9%
Estimate against measurement, compound 3: 17.9 percentage points below, and the stated range ends below it.
By their numbers in this assay, from the lowest: compounds 1 and 2 (each within the scatter of the next); then compound 3.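

Drawing the stereocentre at a saturated chain carbon R rather than S gives a number 18 percentage points higher from compound 2 to compound 3 (beyond the scatter) in this assay, the only step in the series so far and one beyond the scatter. No group enters or leaves, so the shift is tied to configuration alone, because of this: the fact that compounds 2 and 3 differ only in the configuration as drawn

Still open, on these data alone, is whether the R configuration gives a step of this kind when a morpholine amide stands in place of the piperidine amide. The compounds shown also do not say which part of the whole-organism handling of compound 3 changes with configuration.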